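The source may hold more compounds than are shown below. What is called first, only, known or untested is meant among the compounds shown, and "the series" means these compounds.

Measured in a functional assay on MIA PaCa-2 cells (Homo sapiens) for antiproliferative activity, read by sulforhodamine B assay, with a stated time of 48 h; a lower number here means a stronger inhibitor, a higher number a weaker inhibitor:
- Compound 1 `COc1cc(C(=O)/C=C\Nc2ccc(-c3nc4cc(OC)c(OC)c(OC)c4s3)cc2C)cc([N+](=O)[O-])c1OC`: 22000 nM
- Compound 2 `COc1ccc(C(=O)/C=C\Nc2ccc(-c3nc4cc(OC)c(OC)c(OC)c4s3)cc2)cc1[N+](=O)[O-]`: 15900 nM
- Compound 3 `COc1ccc(C(=O)/C=C\Nc2ccc(-c3nc4cc(OC)c(OC)c(OC)c4s3)cc2)cc1F`: 19400 nM

Compound 2, at 15900 nM, lies within the scatter of both other compounds, so none of the three stands apart. The next compound to be tested, compound 4 `COc1cc(C(=O)/C=C\Nc2ccc(-c3nc4cc(OC)c(OC)c(OC)c4s3)cc2)cc([N+](=O)[O-])c1OC`, differs from compound 2 by one change: methoxy in place of hydrogen on an aromatic carbon. This puts a methoxy in place of hydrogen on an aromatic carbon, ortho to a methoxy group and meta to a nitro group.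

Going by the values given here, no measured step tests this exact change. The nearest evidence is a 1.2-fold higher number from compound 2 to compound 3 (0.09 log units; within the scatter), a swap of fluoro in place of nitro on the same ring, and it stays within the scatter. Compound 1 also carries the extra methoxy, and compound 1 at 22000 nM is within the scatter of compound 2. No step beyond the scatter is therefore expected in this assay, and no direction can be favoured. The expected step is a 1.1-fold higher number from compound 2 to compound 4 (0.05 log units; within the scatter). For compound 4 the estimated value is 18000 nM, with an expected range from 8000 nM to 40000 nM.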

Compound 4, half-maximal inhibitory concentration: 15800 nM
For compound 4 the middle estimate is 1.1-fold (0.06 log units) above the measured one, and the stated range covers the measured number.
By their numbers in this assay, from the lowest: compounds 4, 2, 3 and 1 (each within the scatter of the next).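

In this assay, a methoxy in place of hydrogen on an aromatic carbon, ortho to a methoxy group and meta to a nitro group, gives a 1.0-fold lower number from compound 2 to compound 4 (0.00 log units; within the scatter) and so stays within the scatter, which gives this position its first direct test. The methyl of compound 1 can also now be read alone: hydrogen in its place on an aromatic carbon gives a 1.4-fold lower number from compound 1 to compound 4 (0.14 log units; within the scatter) and also stays within the scatter. No measurement here explains why either change leaves the number within the scatter.

On these data alone, whether another group at this position, such as an amine, a carboxylic acid or a longer chain, would give a step beyond the scatter remains open. So does what the same methoxy would do with fluoro in place of the nitro group.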